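Replacing the benzyl-type arm of compound 1 with a short chain

A few compounds are considered here, and "the series" means these few. Any claim that something is new, unique, unknown or untested is made for them only; others in the source may bear on it.

Measured so far:
compound 1, `Clc1cccc(Cn2ccc3nc(-c4ccccc4)nc-3c2)c1`, > 100000 nM
compound 2, `FC(F)(F)c1ccccc1Cn1ccc2nc(-c3ccccc3)nc-2c1`, > 100000 nM
compound 3, `FC(F)(F)c1cccc(Cn2ccc3nc(-c4ccccc4)nc-3c2)c1`, 98000 nM

In an ADME assay on MDBK cells (Bos taurus) for cytotoxicity (on this read-out higher numbers stand for lower toxicity in this test and lower numbers for higher toxicity in this test), compound 1 gives only a limit, > 100000 nM, not a number. Compound 2 likewise sits at a limit in this assay, > 100000 nM. Compound 3 gives a number in this assay, 98000 nM, and that value lies close to the limit of > 100000 nM in this assay, at which 2 of the 3 values shown sit.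

The unmeasured compound 4, `CC(C)CCn1ccc2nc(-c3ccccc3)nc-2c1`, differs from compound 1 as follows: isobutyl in place of 3-chlorophenyl on a saturated chain carbon bound to an aromatic nitrogen. For the measured compounds named here, the only measured step is an at least 1.0-fold lower number from compound 1 to compound 3 (0.00 log units; that floor lies within the scatter); it swaps one substituent on the aromatic ring for another and does not touch the chain, so it says nothing direct about exchanging the whole 3-chlorophenyl for isobutyl. Going by the values given here, what the three values do show is that every compound measured so far sits at or near the limit of this assay.

Among the compounds with values here, with no step that bears on the change, the expectation is that compound 4 shows no step beyond the scatter, a number no higher from compound 1 to compound 4 (the limit leaves the size open), and most likely returns a limit again. Compound 4 is therefore estimated at 100000 nM, within 50000 nM to 200000 nM.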

Compound 4, half-maximal cytotoxic concentration: > 100000 nM
Compound 4: only a limit was reported; the forecaster's own chance of this, stated with the estimate: 65%; the middle value sits exactly at the limit.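

In this assay, compound 1 and compound 4 both stand only as limits, so no step can be read between them: the limit of > 100000 nM in this assay, at which 3 of the 4 values shown sit.

The compounds shown leave open whether isobutyl in place of 3-chlorophenyl shifts the half-maximal cytotoxic concentration at all, and in which direction.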